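Swapping the aryl group on the piperazine arm

This account rests on a few compounds, and the source may have more. Where it says the series, first, only, none or still open, it means among the compounds named here.

Compound 1 `S=c1oc(-c2ccc3c(c2)OCCO3)nn1CN1CCN(C(c2ccccc2)c2ccccc2)CC1` gives 9120 nM in a functional assay on HepG2 cells (Homo sapiens) for antiproliferative activity, read by MTT assay, with a stated time of 48 h; on this read-out lower numbers stand for stronger inhibition and higher numbers for weaker inhibition.
Compound 2 `Cc1ccc(N2CCN(Cn3nc(-c4ccc5c(c4)OCCO5)oc3=S)CC2)c(C)c1` gives 28400 nM in this assay.
Compound 3 `COc1ccccc1N1CCN(Cn2nc(-c3ccc4c(c3)OCCO4)oc2=S)CC1` gives 15500 nM in this assay.

Compound 2 shows the highest number of the three. Its nearest neighbour is compound 3, and that step, a 1.8-fold lower number from compound 2 to compound 3 (0.26 log units; within the scatter), stays within the scatter. Compound 1 lies furthest away, and the gap between the values of compound 2 and compound 1 is beyond the scatter.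

Compound 4 `O=[N+]([O-])c1ccc(N2CCN(Cn3nc(-c4ccc5c(c4)OCCO5)oc3=S)CC2)cc1` is not yet measured. It differs from compound 2 as follows: 4-nitrophenyl in place of 2,4-dimethylphenyl on an amine nitrogen in a ring. Among the compounds with values here, the only step that bears on it is the aryl swap from compound 2 to compound 3, which was within the scatter; no other measured pair touches this position. Compound 4 is therefore expected to show a 1.5-fold lower number from compound 2 to compound 4 (0.17 log units; within the scatter), a change not beyond the scatter. Compound 4 is estimated at 19000 nM, expected within 6000 nM to 55000 nM.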

Compound 4, half-maximal inhibitory concentration: 29500 nM
For compound 4 the middle estimate is 1.6-fold (0.19 log units) below the measured one, within the range that was stated.
By their numbers in this assay, from the lowest: compounds 1, 3, 2 and 4 (each within the scatter of the next, the first and the last beyond it).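

With 4-nitrophenyl on the amine nitrogen in a ring, this assay shows a 1.0-fold higher number from compound 2 to compound 4 (0.02 log units; within the scatter), and against 2-methoxyphenyl it shows a 1.9-fold higher number from compound 3 to compound 4 (0.28 log units; within the scatter). The three aryl groups on this nitrogen in compounds 2, 3 and 4 therefore cannot be told apart here, even though 4-nitrophenyl adds hydrogen-bond acceptors and a double bond outside the aromatic ring. Nothing available explains this result.

As far as these compounds go, it remains open whether an unsubstituted phenyl, or a phenyl bearing an amine or a carboxylic acid, would separate from these three.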